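Fluoro Substitution in an Inactive Sulfonamide Series

The source may report more compounds than this note shows. Statements on the series, on what has been measured and on what is new or still open speak of the compounds shown alone.

Measured in an assay on isolated protein for agonist activity at transient receptor potential cation channel subfamily V member 1 (Rattus norvegicus), read by scintillation counting and calcium flux, with a stated time of 10 min, in the presence of a further agent that is not named here; a higher number here means that more compound is needed for the effect, a lower number that less compound is needed:
compound 1, `C[C@@H](NC(=O)CCc1ccc(C(C)(C)C)cc1)c1ccc(NS(C)(=O)=O)cc1`: > 100000 nM
compound 2, `C[C@@H](NC(=S)CCc1ccc(C(C)(C)C)cc1)c1ccc(NS(C)(=O)=O)cc1`: > 100000 nM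
compound 3, `C[C@@H](NC(=O)COc1ccc(C(C)(C)C)cc1)c1ccc(NS(C)(=O)=O)cc1`: > 100000 nM

Compound 3 stands where all three sit, at the limit of > 100000 nM in this assay, at which 3 of the 3 values shown sit; its value in this assay is a limit of the assay and not a number. The same holds for compound 1 in this assay. The same holds for compound 2 in this assay. Going by the values given here, with no measured step in this assay, nothing here shows a change beyond the scatter.

Compound 4, `C[C@@H](NC(=O)COc1ccc(C(C)(C)C)cc1)c1ccc(NS(C)(=O)=O)c(F)c1`, differs from compound 3 by fluoro in place of hydrogen on an aromatic carbon. On the numbers at hand the expectation is that this change gives no step beyond the limit, so the step from compound 3 to compound 4 in this assay is estimated as a number no higher from compound 3 to compound 4 (the limit leaves the size open). Compound 4 is therefore expected at 100000 nM, within 20000 nM to 300000 nM, most likely again as a limit.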

Compound 4, half-maximal effective concentration: > 100000 nM
Compound 4 gave a limit, no number (the forecaster's own chance of this, stated with the estimate: 80%); the middle value lies on the limit itself.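

Compound 3 and compound 4 both give limits and not numbers, so no step between them can be read: the limit of > 100000 nM in this assay, at which 4 of the 4 values shown sit.

The compounds shown leave open what fluoro in place of hydrogen on an aromatic carbon does in a compound with a measurable value.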